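The source may report more compounds than this note shows. Statements on the series, on what has been measured and on what is new or still open speak of the compounds shown alone.

Compound 1 `Cc1ccc(OCC(=O)N(Cc2cccs2)CC(C)C)cc1`: 900 nM
Compound 2 `Cc1ccc(OCC(=O)N(Cc2cccs2)C2CCCCC2)cc1`: 40000 nM
Compound 3 `C=CCN(Cc1cccs1)C(=O)COc1ccc(C)cc1`: 20 nM

In an assay on HEK293 cells for agonist activity at transient receptor potential cation channel subfamily M member 8 (Homo sapiens), read by fluorescence and calcium flux, with a stated time of 15 min (a higher number here means that more compound is needed for the effect, a lower number that less compound is needed), compound 3 gives the lowest of the three numbers; its nearest neighbour is compound 1, and compound 2 stands furthest away. Compound 4 `COCCN(Cc1cccs1)C(=O)COc1ccc(C)cc1` differs from compound 3 in one place: methoxymethyl in place of vinyl on a saturated chain carbon bound to an amide-type nitrogen. Going by the values given here, two measured steps touch this position. The step of a 45-fold lower number from compound 1 to compound 3 (1.65 log units; beyond the scatter) was large, and the step of a 2000-fold lower number from compound 2 to compound 3 (3.30 log units; beyond the scatter) was larger still, so the group on the amide-type nitrogen has moved the numbers strongly in this set; the step of a 44-fold higher number from compound 1 to compound 2 (1.65 log units; beyond the scatter) shows the same in the other direction. Nothing measured here carries an oxygen in this chain, so the effect of the methoxymethyl group is not known. Compound 3 holds the best number, and the measured changes at this site, compound 1 and compound 2, both gave higher numbers than compound 3. The writer therefore expects a higher number for compound 4, with a step of a 15-fold higher number from compound 3 to compound 4 (1.18 log units; beyond the scatter) in this assay. The estimate for compound 4 is 300 nM, within a range from 50 nM to 2000 nM.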

Compound 4, half-maximal effective concentration: 400 nM
For compound 4 the middle estimate is 1.3-fold (0.12 log units) below the measured one, within the range that was stated.
By their numbers in this assay, from the lowest: compound 3; then compound 4; then compound 1; then compound 2.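

In this assay, 2-methoxyethyl, the first chain at this place to carry an oxygen, does not match allyl: a 20-fold higher number from compound 3 to compound 4 (1.30 log units; beyond the scatter). It still stays far from the cyclohexyl end of the set, a 100-fold lower number from compound 2 to compound 4 (2.00 log units; beyond the scatter), and it lies only modestly under the branched isobutyl chain, a 2.3-fold lower number from compound 1 to compound 4 (0.35 log units; beyond the scatter), so an open chain with a hydrogen-bond acceptor is tolerated better than cyclohexyl but does not reach the number of the allyl compound. No measured evidence is available to explain these steps.

The compounds shown do not separate the oxygen that enters from the double bond that leaves, a split that a plain propyl chain on the amide-type nitrogen would address. On these data alone, how a 2-aminoethyl chain or a propargyl group would stand at this place also remains open.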